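Microsomal stability: from compound 3 to compound 4

The compounds below may be only part of what the source reports. "The series", "measured", "known", "first", "only" and "open" are said of these compounds alone.

Measured so far in an ADME assay on microsomes from liver (Homo sapiens) for metabolic stability; a higher number here means that the compound lasts longer, a lower number that the compound disappears faster:
- compound 1 `CCn1ncc2c(F)cc(-c3ccc(C(CC)(CC)c4nnc(C)[nH]4)c(=O)[nH]3)cc21` gives > 3 h, a limit of the assay.
- compound 2 `CCn1ncc2c(F)cc(-c3ccc(C(CC)(CC)c4ncn(C)n4)c(=O)[nH]3)cc21` gives > 3 h, also a limit of the assay.
- compound 3 `CC(C)C(/C=C1\CCNC1=O)c1ccc(-c2ccc3cccc(F)c3c2)[nH]c1=O` gives 0.713 h.

Going by the values given here, compound 3 thus holds the only number in this assay; the other two values are limits, as recorded in the limit of > 3 h in this assay, at which 2 of the 3 values shown sit. Among the compounds with values here, the single step between measured compounds, a step that the two limits leave unreadable from compound 1 to compound 2, lies between two limits and its size cannot be read.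

Compound 4 `CC(C)C(c1ncco1)c1ccc(-c2ccc3cccc(F)c3c2)[nH]c1=O` differs from compound 3 by a group of 5 heavy atoms (3 carbon, 1 nitrogen, 1 oxygen; one five-membered aromatic ring with 2 hetero atoms) in place of a group of 7 heavy atoms (5 carbon, 1 nitrogen, 1 oxygen; one five-membered non-aromatic ring with 1 hetero atom), on a saturated chain carbon bound to an aromatic carbon and a saturated chain carbon. Within the data shown here, no measured step covers this change; the one recorded step concerns another place and is itself unreadable. The step of a 1.1-fold higher number from compound 3 to compound 4 (0.05 log units; within the scatter) is therefore expected to stay within the usual scatter. Compound 4 is estimated at 0.8 h in this assay, with a range from 0.35 h to 2 h.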

Compound 4, half-life: 0.178 h
Compound 4: the middle estimate sits 4.5-fold (0.65 log units) above what was measured, outside the stated range (below it).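

In this assay, going by these compounds alone, the change to 1,3-oxazol-2-yl on a saturated chain carbon bound to an aromatic carbon and a saturated chain carbon gives a 4.0-fold lower number from compound 3 to compound 4 (0.60 log units; beyond the scatter) and is the first readable step. Within the data shown here, this place therefore responds to the group it carries, which the earlier compounds could not show. Nothing on record accounts for the size of this step.

Going by these compounds, whether an amine or a carboxylic acid at this place would give a longer or shorter half-life stays open. Also open, on these data alone, is whether the same change would have a similar effect on the core of compound 1.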